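Changing the Group on the Benzyl Ring: Solubility Outlook

The source may report more compounds than this note shows. Statements on the series, on what has been measured and on what is new or still open speak of the compounds shown alone.

Compound 1, `CNC(=O)c1cc(C(=O)NC2CC2)c(C)n(Cc2ccccc2)c1=O`: 577 ug/mL
Compound 2, `CNC(=O)c1cc(C(=O)NC2CCC2)cn(Cc2ccccc2)c1=O`: 24 ug/mL
Compound 3, `CNC(=O)c1cc(C(=O)NC2CC2)cn(Cc2ccc(OC)cc2)c1=O`: 263 ug/mL

These numbers come from a physicochemical assay for solubility, read by HPLC, in simulated intestinal fluid, with a stated time of 16 h, tested at 125 ug/mL; a lower number here means a less soluble compound, a higher number a more soluble compound. Among the three, compound 3 stands second highest: compound 1 sits above it by a gap beyond the usual scatter, and compound 2 sits far below it. Compound 4, `CNC(=O)c1cc(C(=O)NC2CC2)cn(Cc2cccc(C)c2)c1=O`, has not yet been measured. It differs from compound 3 in a single place: 3-methylphenyl in place of 4-methoxyphenyl on a saturated chain carbon bound to an aromatic nitrogen. Within the data shown here, no measured pair shows this same change, so its size cannot be read from the data. A modest drop is expected, close to the edge of the scatter, as the expected step of a 1.8-fold lower number from compound 3 to compound 4 (0.24 log units; within the scatter). Compound 4 is therefore estimated at 150 ug/mL, within a range from 50 ug/mL to 400 ug/mL.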

Compound 4, solubility: 88 ug/mL
For compound 4 the middle estimate is 1.7-fold (0.23 log units) above the measured one; measured number inside the range.
By their numbers in this assay, from the lowest: compound 2; then compound 4; then compound 3; then compound 1.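

Among these compounds, putting 3-methylphenyl in place of 4-methoxyphenyl on a saturated chain carbon bound to an aromatic nitrogen gives the first single-place step in this assay, a 3.0-fold lower number from compound 3 to compound 4 (0.48 log units; beyond the scatter), and this was not visible from the earlier compounds. It shows that the group at this position can move the number beyond the usual scatter. Nothing here accounts for the size of this step.

On these data alone, since the group and its printed ring number both change, 4-methylphenyl and 3-methoxyphenyl remain open as the groups that could separate the two. As far as these compounds go, how a phenyl ring carrying an amine or a carboxylic acid would compare at this position also remains open.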